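Pyridin-2-yl for 4-fluorophenyl: series notes toward compound 4

This account rests on a few compounds, and the source may have more. Where it says the series, first, only, none or still open, it means among the compounds named here.

Measured so far in an assay on HEK293 cells for inhibition of N-acylethanolamine-hydrolyzing acid amidase (Rattus norvegicus), read by LC-MS, with a stated time of 30 min; a higher number here means a weaker inhibitor, a lower number a stronger inhibitor:
- Compound 1, `Cc1ccc(-c2ccc(CCC(=O)N3CCCC3)cc2)cc1`; compound 1 gives 33200 nM.
- Compound 2, `O=C(CCc1ccc(-c2ccc(F)cc2)cc1)N1CCCC1`; compound 2 gives 3400 nM.
- Compound 3, `COc1cccc(CCCCCCC(=O)N2CCCC2)c1`; for compound 3 the assay records only a limit, > 100000 nM, not a number.

Compound 2 holds the lowest of the two numbers in this assay. For the measured compounds named here, its nearest neighbour is compound 1, and the single measured step, a 9.8-fold lower number from compound 1 to compound 2 (0.99 log units; beyond the scatter), covers fluoro in place of methyl on an aromatic carbon and lies beyond the scatter. Compound 3 sits at the limit of > 100000 nM in this assay, at which 1 of the 3 values shown sits, and gives no number to compare against.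

Compound 4, `O=C(CCc1ccc(-c2ccccn2)cc1)N1CCCC1`, differs from compound 2 by pyridin-2-yl in place of 4-fluorophenyl on an aromatic carbon. Going by the values given here, no measured step swaps the whole terminal ring; the only step on that ring, a 9.8-fold lower number from compound 1 to compound 2 (0.99 log units; beyond the scatter), changes a single substituent and shows the terminal ring is sensitive to substitution. The change to compound 4 removes the fluoro that distinguished compound 2 from compound 1, so a move back toward weaker inhibition is expected, though the direction is uncertain without a closer precedent.

For compound 4 the expected step in this assay is a 2.9-fold higher number from compound 2 to compound 4 (0.47 log units; beyond the scatter). Compound 4 is therefore estimated at 10000 nM, within a range from 3000 nM to 40000 nM.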

Compound 4, half-maximal inhibitory concentration: > 100000 nM
Compound 4: a limit, no number; the forecaster's own chance of this, stated with the estimate: 10%; at least 10-fold (1.00 log units) between middle value and limit.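

Compound 4 gives a limit rather than a number in this assay, and this places it at the top of the measurable range: the limit of > 100000 nM in this assay, at which 2 of the 4 values shown sit.

The earlier step only exchanged one substituent on a carbon-only terminal ring, whereas this change replaces the ring itself, with an at least 29-fold higher number from compound 2 to compound 4 (1.46 log units; beyond the scatter) and, against the weaker of the two measured biaryl amides, an at least 3.0-fold higher number from compound 1 to compound 4 (0.47 log units; beyond the scatter). At this position, on an aromatic carbon para to a group of 9 heavy atoms, the identity of the terminal ring therefore matters at least as much as the substituent it carries, and pyridin-2-yl gives up all of the measurable inhibition seen with 4-fluorophenyl and 4-methylphenyl.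

The swap removes the fluoro and brings in the ring nitrogen in a single move, so the compounds shown do not separate the two contributions. Unsubstituted phenyl would isolate the loss of the fluoro, while a fluoro-bearing pyridin-2-yl or a pyridin-3-yl ring would show whether any ring nitrogen at this position can be accommodated.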